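A few compounds are considered here, and "the series" means these few. Any claim that something is new, unique, unknown or untested is made for them only; others in the source may bear on it.

Compound 1 `Cc1cc(NC(=O)Nc2ccc(N)cc2)c2ccccc2n1` in an ADME assay on BJ cells (Homo sapiens) for cytotoxicity, with a stated time of 72 h (a higher number here means that more compound is needed for the effect, a lower number that less compound is needed), gives > 25000 nM, which is a limit of the assay and not a number.
Compound 2 `Cc1cc(NC(=O)Nc2ccc(O)cc2)c2ccccc2n1` in this assay gives > 25000 nM, again a limit.
Compound 3 `Cc1cc(NC(=O)Nc2ccc(C(N)=O)cc2)c2ccccc2n1` in this assay gives > 25000 nM, also a limit.

Compound 3 therefore stands at the same limit as the other two measured compounds, all three sitting at the limit of > 25000 nM in this assay, at which 3 of the 3 values shown sit. Among the measured compounds shown here, no measured compound in this set has produced a number, so compound 3 cannot be ranked against compounds 1 or 2.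

The compound to be measured next is compound 4 `Cc1cc(NC(=O)Nc2ccc(C(C)(C)C)cc2)c2ccccc2n1`. Its difference from compound 3 is tert-butyl in place of carbamoyl on an aromatic carbon.

Three measured steps exist: a step that the two limits leave unreadable from compound 1 to compound 2, a step that the two limits leave unreadable from compound 1 to compound 3 and a step that the two limits leave unreadable from compound 2 to compound 3. All three are unreadable in size, since both ends of each sit at the limit. None of them involves a tert-butyl group, so none bears directly on the change to compound 4, and they offer no readable size or direction to expect in this assay.

Given that every measured value is a limit, compound 4 is expected to sit at or near the limit as well, with the step estimated as a step that the limit leaves unreadable from compound 3 to compound 4. The estimated value for compound 4 is 30000 nM, within a range from 8000 nM to 100000 nM.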

Compound 4, half-maximal effective concentration: 20000 nM
Compound 4: the middle estimate sits 1.5-fold (0.18 log units) above what was measured; measured number inside the range.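

Among the compounds shown here, at this position on the aromatic ring, tert-butyl is the first group to give a number in this assay, while amino, hydroxy and carbamoyl all remain at a limit of the assay: the limit of > 25000 nM in this assay, at which 3 of the 4 values shown sit. Placing tert-butyl there gives an at least 1.2-fold lower number from compound 3 to compound 4 (0.09 log units; that floor lies within the scatter) and an at least 1.2-fold lower number from compound 2 to compound 4 (0.09 log units; that floor lies within the scatter) and also an at least 1.2-fold lower number from compound 1 to compound 4 (0.09 log units; that floor lies within the scatter) as the third such floor. As far as these compounds go, each step is only a floor, so the true size of the change stays unknown, and the steps among compound 1, compound 2 and compound 3 still cannot be read.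

The compounds shown leave open whether a smaller alkyl group such as methyl or isopropyl would also give a number at this position. They also leave open what a carboxylic acid or a longer chain would do there.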